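The source may report more compounds than this note shows. Statements on the series, on what has been measured and on what is new or still open speak of the compounds shown alone.

Measured so far:
compound 1, `CC(C)(C)C1=C(C(=O)O)N2C(=O)[C@H](CO)[C@H]2O1`, gives 5 h in an ADME assay, in phosphate buffer, at 28 degrees C, at pH 7.0; on this read-out higher numbers stand for a longer-lived compound and lower numbers for a shorter-lived compound
compound 2, `CC(C)(C)C1=C(C(=O)O)N2C(=O)[C@H]([C@H](O)CCc3ccncc3)[C@H]2O1`, gives 13.7 h in this assay

Compound 1 holds the lowest of the two numbers in this assay; its nearest neighbour is compound 2, reached by a 2.7-fold higher number from compound 1 to compound 2 (0.44 log units; beyond the scatter). Compound 3, `Cn1cc([C@H](O)[C@H]2C(=O)N3C(C(=O)O)=C(C(C)(C)C)O[C@H]23)nn1`, has not yet been measured in this assay. It differs from compound 1 by 1-methyl-1H-1,2,3-triazol-4-yl in place of hydrogen on a saturated chain carbon bound to an oxygen on a saturated carbon and a saturated ring carbon. Among the measured compounds shown here, the only measured step that bears on this change is the one at the same place, a 2.7-fold higher number from compound 1 to compound 2 (0.44 log units; beyond the scatter), where a different group entered on the same saturated chain carbon. Compound 2 shows that a group at this position can lengthen the half-life beyond the scatter, but the entering group in compound 3 is not the one that was measured, so the size of the step cannot be read off directly. Compound 3 is expected to show a modest rise, a 1.8-fold higher number from compound 1 to compound 3 (0.26 log units; within the scatter), with a range wide enough to take in no change at all. Compound 3 is therefore estimated at 9 h in this assay, between 4 h and 20 h.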

Compound 3, half-life: 7 h
Compound 3: the middle estimate sits 1.3-fold (0.11 log units) above what was measured; the range from low to high includes it.
By their numbers in this assay, from the lowest: compounds 1, 3 and 2 (each within the scatter of the next, the first and the last beyond it).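

In this assay, 1-methyl-1H-1,2,3-triazol-4-yl on the saturated chain carbon gives a 1.4-fold higher number from compound 1 to compound 3 (0.15 log units; within the scatter), so this entering group, unlike the 2-(pyridin-4-yl)ethyl group in the earlier step, a 2.7-fold higher number from compound 1 to compound 2 (0.44 log units; beyond the scatter), leaves the half-life within the scatter of compound 1. A step beyond the scatter at this position therefore does not hold for every entering group, although compound 2 at 13.7 h and compound 3 at 7 h stand within the scatter of each other, so the two groups cannot be told apart by direct comparison of these values. No measurement shown here accounts for the outcome of this change.

The compounds shown leave open whether the step to compound 2 goes with the pyridine ring or with the ethyl chain that carries it, a question that a 2-phenylethyl group or a plain ethyl group on the same saturated chain carbon would address. They also leave open how the half-life would respond to a methoxy group in place of the hydroxyl on this carbon.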